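The source may report more compounds than this note shows. Statements on the series, on what has been measured and on what is new or still open speak of the compounds shown alone.

Measured so far:
Compound 1 `O=C(NCc1cc(Cl)ccc1-n1cnnn1)[C@@H]1C[C@@H]2C[C@@H]2N1C(=O)[C@H](O)Cc1ccccn1` gives 1000 nM in a functional assay on a cell-free system (plasma, Homo sapiens), with a stated time of 3 min; on this read-out lower numbers stand for stronger inhibition and higher numbers for weaker inhibition.
Compound 2 `CC(C)(C)[C@@H](O)C(=O)N1OCC[C@H]1C(=O)NCc1cc(Cl)ccc1-n1cnnn1` gives 1600 nM in this assay.

Compound 2 stands at the top of the two numbers shown, yet its gap to compound 1 lies within the usual scatter, so the two cannot be told apart. Compound 3 `CC(C)(C)C[C@@H](O)C(=O)N1OCC[C@H]1C(=O)NCc1cc(Cl)ccc1-n1cnnn1` differs from compound 2 by neopentyl in place of tert-butyl on a saturated chain carbon bound to a carbonyl carbon and an oxygen on a saturated carbon. For the measured compounds named here, no step between measured compounds shows what such a change does here, so the data give no direction for it. The expected step from compound 2 to compound 3 is a 1.3-fold lower number from compound 2 to compound 3 (0.12 log units; within the scatter), nothing beyond the scatter. Compound 3 is therefore estimated at 1200 nM, within a range from 400 nM to 3600 nM.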

Compound 3, half-maximal inhibitory concentration: 1100 nM
The estimate for compound 3 lay 1.1-fold (0.04 log units) above the measured number, and the stated range covers the measured number.
By their numbers in this assay, from the lowest: compounds 1, 3 and 2 (each within the scatter of the next).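

Neopentyl in place of tert-butyl on this saturated chain carbon gives a 1.5-fold lower number from compound 2 to compound 3 (0.16 log units; within the scatter), the first step read at this position. In this assay, this change therefore makes no difference that can be told from the scatter, so these two groups cannot be separated here. No measured evidence on the result is available to explain it. Going by these compounds, what an amine, a carboxylic acid or a phenyl ring would do at this position stays open. So does whether a longer chain would also stay within the scatter of these compounds.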